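Side-chain swaps on a weak amine oxidase inhibitor

A few compounds are considered here, and "the series" means these few. Any claim that something is new, unique, unknown or untested is made for them only; others in the source may bear on it.

Compound 1 `COC(=O)[C@H](C)NC(=O)c1ccc(NC(=O)C(=O)c2ccccc2NC(C)=O)cc1` gives 730000 nM in an assay on mitochondria from brain for inhibition of Amine oxidase [flavin-containing] B (Bos taurus); a higher number here means a weaker inhibitor, a lower number a stronger inhibitor.
Compound 2 `COC(=O)[C@@H](NC(=O)c1ccc(NC(=O)C(=O)c2ccccc2NC(C)=O)cc1)C(C)C` gives 430000 nM in this assay.
Compound 3 `COC(=O)C[C@H](NC(=O)c1ccc(NC(=O)C(=O)c2ccccc2NC(C)=O)cc1)C(=O)OC` gives 790000 nM in this assay.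

Compound 3 sits at the top of these three numbers, yet a 1.1-fold higher number from compound 1 to compound 3 (0.03 log units; within the scatter) and a 1.8-fold higher number from compound 2 to compound 3 (0.26 log units; within the scatter) both fall within the scatter, as does a 1.7-fold lower number from compound 1 to compound 2 (0.23 log units; within the scatter), so the three cannot be told apart. Compound 4 `COC(=O)CCCCCNC(=O)c1ccc(NC(=O)C(=O)c2ccccc2NC(C)=O)cc1` differs from compound 3 by 5-(methoxycarbonyl)pentyl in place of 1,2-bis(methoxycarbonyl)ethyl on an amide-type nitrogen. Every measured step also exchanged the group on that amide-type nitrogen, and none moved the number beyond the scatter, so for compound 4 no step beyond the scatter is expected, namely a 1.3-fold lower number from compound 3 to compound 4 (0.12 log units; within the scatter). Compound 4 is therefore estimated at 600000 nM, with a range from 200000 nM to 2000000 nM.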

Compound 4, half-maximal inhibitory concentration: 780000 nM
Compound 4: middle estimate off by 1.3-fold (0.11 log units), on the low side; the measured number falls inside the stated range.
By their numbers in this assay, from the lowest: compounds 2, 1, 4 and 3 (each within the scatter of the next).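

In this assay, the 5-(methoxycarbonyl)pentyl group on the amide-type nitrogen cannot be told apart from any of the three earlier groups (a 1.0-fold lower number from compound 3 to compound 4 (0.01 log units; within the scatter); a 1.8-fold higher number from compound 2 to compound 4 (0.26 log units; within the scatter); a 1.1-fold higher number from compound 1 to compound 4 (0.03 log units; within the scatter)). Even the step from 1,2-bis(methoxycarbonyl)ethyl, which removes a methoxycarbonyl group and the defined stereocentre, leaves the number in place, so neither feature is needed to hold this weak level. No supporting measurement bears on this result.

Still open, as far as these compounds go, is whether a carboxylic acid or an amine in place of the methoxycarbonyl group would move the number beyond the scatter.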